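Hydroxamic acid chain length in the indole series

The source may report more compounds than this note shows. Statements on the series, on what has been measured and on what is new or still open speak of the compounds shown alone.

Working notes on a small set of hydroxamic acids tested in a functional assay on LNCaP cells (Homo sapiens) for inhibition, read by MTT assay, with a stated time of 72 h; on this read-out higher numbers stand for weaker inhibition and lower numbers for stronger inhibition. Compound 1 `Cc1ccc(-c2cc(C(=O)NCCCCCCC(=O)NO)nn2-c2ccc(S(N)(=O)=O)cc2)cc1` reaches only the limit of the assay, > 20000 nM. Compound 2 `COC(=O)Cc1c(C)n(Cc2ccc(-c3cn(CCCCCC(=O)NO)nn3)cc2)c2ccc(OC)cc12` likewise gives only a limit in this assay, > 20000 nM. For compound 3 `COc1ccc2c(c1)c(CC(=O)O)c(C)n2Cc1ccc(-c2cn(CCCCCCC(=O)NO)nn2)cc1` the entry in this assay reads "not determined" (no result reported), so no number is available. Going by the values given here, compound 2 therefore stands at the limit of > 20000 nM in this assay, at which 2 of the 3 values shown sit, with no single measured value in the set to compare against, and no step between measured compounds can be drawn.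

The untested compound 4 `COC(=O)Cc1c(C)n(Cc2ccc(-c3cn(CCCCCCCC(=O)NO)nn3)cc2)c2ccc(OC)cc12` differs from compound 2 by 2-(hydroxycarbamoyl)ethyl in place of hydroxycarbamoyl on a saturated chain carbon, five bonds along the chain from an aromatic nitrogen. Compound 4 is expected to move by an at least 1.6-fold lower number from compound 2 to compound 4 (0.22 log units; that floor lies within the scatter), though the change could fall anywhere from none beyond the scatter to a modest gain. The estimate for compound 4 is 12000 nM, within 3000 nM to 40000 nM.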

Compound 4, half-maximal inhibitory concentration: 1530 nM
Compound 4: middle estimate off by 7.8-fold (0.89 log units), on the high side; measured number outside the range, below it.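

In this assay, 2-(hydroxycarbamoyl)ethyl in place of hydroxycarbamoyl on a saturated chain carbon, five bonds along the chain from an aromatic nitrogen, gives an at least 13-fold lower number from compound 2 to compound 4 (1.11 log units; beyond the scatter). Going by these compounds alone, this is the first sign in the set that the number responds to chain length at this position, and compound 4 gives the first single value. The full size of the step stays unknown, as compound 2 is only a limit: the limit of > 20000 nM in this assay, at which 2 of the 4 values shown sit.

On these data alone, whether a longer chain than that of compound 4 lowers the number further or reverses the gain remains open. One step alone sets no trend along the chain.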